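This account rests on a few compounds, and the source may have more. Where it says the series, first, only, none or still open, it means among the compounds named here.

The series shares the core of compound 1 `O=C1/C(=C\c2c(Cl)cccc2Cl)c2ccccc2N1c1c(Cl)cccc1Cl`, which in a functional assay on HuTu80 cells (Homo sapiens) for cytotoxicity, read by MTT assay, with a stated time of 72 h (a higher number here means that more compound is needed for the effect, a lower number that less compound is needed), gives 100 ug/mL. Compound 3 `O=C1/C(=C\c2cccc(Oc3ccccc3)c2)c2ccccc2N1c1c(Cl)cccc1Cl` gives 10 ug/mL in this assay, a figure beyond the scatter from that of compound 1; of the two compounds with a number, compound 1 therefore stands at the higher end. Compound 2 `O=C1/C(=C\c2cc3ccccc3nc2Cl)c2ccccc2N1c1c(Cl)cccc1Cl` has in this assay only "not determined" (no result reported). Among the compounds with values here, no two measured compounds differ in a single place, so no step in this assay has been measured directly.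

Compound 4 `COc1ccc(/C=C2\C(=O)N(c3c(Cl)cccc3Cl)c3ccccc32)cc1` differs from compound 1 by 4-methoxyphenyl in place of 2,6-dichlorophenyl on a double-bonded chain carbon bound to a double-bonded ring carbon. Within the data shown here, none of the measured compounds carries the entering group. The only scale available is that compound 1 gives 100 ug/mL while compound 3 gives 10 ug/mL, so a change of aryl group on that chain carbon can move the number well beyond the scatter. A downward step a 3.3-fold lower number from compound 1 to compound 4 (0.52 log units; beyond the scatter) in this assay is expected, of moderate size and not firmly beyond the scatter. For compound 4 the estimate is 30 ug/mL, with a range from 5 ug/mL to 150 ug/mL.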

Compound 4, concentration for half-maximal effect: > 100 ug/mL
Compound 4 gave a limit, no number (the forecaster's own chance of this, stated with the estimate: 15%); at least 3.3-fold (0.52 log units) between middle value and limit.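

Within the data shown here, replacing 2,6-dichlorophenyl with 4-methoxyphenyl on a double-bonded chain carbon bound to a double-bonded ring carbon gives the first direct step at this position in this assay, with this outcome: a number no lower from compound 1 to compound 4 (the limit leaves the size open). Compound 4 gives > 100 ug/mL, which is a limit and not a number. The direction of this step can therefore be read, but not its size, and exchanging one aryl group for another at this position does not by itself lower the number.

Among these compounds, compound 3 gives 10 ug/mL, but no single step shows how much of that value belongs to its phenoxy-bearing aryl group. Also open, on these data alone, is how the number would respond to a dimethylamino group or a carboxylic acid in place of the methoxy group on this aryl ring.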